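Removing the para methyl from compound 1

The source may hold more compounds than are shown below. What is called first, only, known or untested is meant among the compounds shown, and "the series" means these compounds.

Measured compounds:
compound 1 `Cc1ccc(-n2cc(CNC(=O)c3cccc4c3cnn4C(C)C)nn2)c(C)c1`: 10600 nM
compound 2 `CC(C)n1ncc2c(C(=O)NCc3cn(-c4ccc(I)cc4)nn3)cccc21`: > 40000 nM (a limit)
compound 3 `Cc1ccc(-n2cc(CNC(=O)c3cccc4c3cnn4C(C)C)nn2)cc1`: 39000 nM

In a functional assay on PC-3 cells (Homo sapiens) for inhibition, read by MTT assay, with a stated time of 72 h (on this read-out lower numbers stand for stronger inhibition and higher numbers for weaker inhibition), compound 1 gives 10600 nM, the lowest of the two numbers shown. Compound 2 reports only a limit, > 40000 nM (the limit of > 40000 nM in this assay, at which 1 of the 3 values shown sits). Compound 3 gives 39000 nM in this assay. The steps are an at least 3.7-fold higher number from compound 1 to compound 2 (0.57 log units; beyond the scatter) and a 3.7-fold higher number from compound 1 to compound 3 (0.57 log units; beyond the scatter), while an at least 1.0-fold lower number from compound 2 to compound 3 (0.01 log units; that floor lies within the scatter).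

Compound 4 `Cc1ccccc1-n1cc(CNC(=O)c2cccc3c2cnn3C(C)C)nn1` differs from compound 1 by hydrogen in place of methyl on an aromatic carbon. For the measured compounds named here, the one measured loss of a methyl, a 3.7-fold higher number from compound 1 to compound 3 (0.57 log units; beyond the scatter), took the other methyl and cost potency; no step on this methyl alone is measured. A weakening of similar size is expected, a 2.4-fold higher number from compound 1 to compound 4 (0.37 log units; beyond the scatter). Compound 4 is therefore estimated at 25000 nM (range 10000 nM to 60000 nM).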

Compound 4, half-maximal inhibitory concentration: 19200 nM
Compound 4: the middle estimate sits 1.3-fold (0.11 log units) above what was measured; measured number inside the range.
By their numbers in this assay, from the lowest: compounds 1 and 4 (each within the scatter of the next); then compound 3. At a limit, above all of these: compound 2.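

In this assay the methyl para to a large group can be lost with no change beyond the scatter (a 1.8-fold higher number from compound 1 to compound 4 (0.26 log units; within the scatter)). With a single methyl left on the ring, 2-methylphenyl gives a lower number than 4-methylphenyl (a 2.0-fold lower number from compound 3 to compound 4 (0.31 log units; beyond the scatter)), so the two methyl positions do not count equally. Compound 2 is only a limit, and 2-methylphenyl also reads lower than its 4-iodophenyl (an at least 2.0-fold lower number from compound 2 to compound 4 (0.31 log units; beyond the scatter)).

Open, on these data alone, is how a methoxy group or an amine at the para position would read. Also open, as far as these compounds go, is whether any group there can bring the number well under that of compound 1 (10600 nM).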